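Trading a Pyrazole for an Ethoxy Group: Oral Exposure

The compounds below may be only part of what the source reports. "The series", "measured", "known", "first", "only" and "open" are said of these compounds alone.

Two measured compounds share a core and differ in the group carried on one aromatic ring. Compound 1 `Cc1cc(C)n(-c2ccc(Cl)c(C(=O)NC(=O)Nc3nc4ccc(S(=O)(=O)CCCN5CCN(C)CC5)cc4s3)c2)n1` was tested in an ADME assay on the whole organism (strain Han-Wistar) for pharmacokinetics, with Rattus norvegicus as the target, read by LC-MS, at a dose of 2 mg/kg by the oral route (on this read-out lower numbers stand for lower exposure and higher numbers for higher exposure at the dose given), where compound 1 gives 78 nM. Compound 2 `CN1CCN(CCCS(=O)(=O)c2ccc3nc(NC(=O)NC(=O)c4cc(-n5cccn5)c(Cl)cc4Cl)sc3c2)CC1` in this assay gives 30 nM. Of the two numbers, compound 1 stands highest, and the gap to compound 2 lies beyond the usual scatter.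

Compound 3 `CCOc1ccc(Cl)c(C(=O)NC(=O)Nc2nc3ccc(S(=O)(=O)CCCN4CCN(C)CC4)cc3s2)c1` has not yet been measured. It differs from compound 1 in one place: ethoxy in place of 3,5-dimethyl-1H-pyrazol-1-yl on an aromatic carbon. The 3,5-dimethyl-1H-pyrazol-1-yl leaves and ethoxy enters on an aromatic carbon of a six-membered aromatic ring of carbon only, meta to a large group and para to a chloro group.

Going by the values given here, no measured pair shows what this exchange does to plasma exposure, so the expectation rests on the two numbers alone and is uncertain. A modest step is expected from compound 1 to compound 3, a 1.3-fold higher number from compound 1 to compound 3 (0.11 log units; within the scatter), not clearly beyond the scatter. Compound 3 in this assay is estimated at 100 nM, with a likely range from 35 nM to 280 nM.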

Compound 3, maximal plasma concentration: 4200 nM
The estimate for compound 3 lay 42-fold (1.62 log units) below the measured number, outside the stated range (above it).
By their numbers in this assay, from the lowest: compound 2; then compound 1; then compound 3.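

In this assay, replacing 3,5-dimethyl-1H-pyrazol-1-yl with ethoxy gives a 54-fold higher number from compound 1 to compound 3 (1.73 log units; beyond the scatter) and counts as a large step. This shows that the aromatic carbon meta to a large group and para to a chloro group is far from a neutral place in this series: a change at this one position, with the rest of the molecule held constant, can move the maximal plasma concentration by much more than the usual scatter. The exchange removes a group of 7 heavy atoms with one five-membered aromatic ring and puts in a group of 3 heavy atoms with no ring, so the group on this carbon matters greatly for oral exposure at the dose given.

This single exchange does not separate the loss of the ring from the change in group size or the arrival of the oxygen, and it leaves open whether methoxy, a longer propoxy chain or a dimethylamino group on the same carbon would behave like ethoxy. Nothing available here explains why the exposure rises so strongly.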